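Swapping an acid for an amide on an arginase binder

This account rests on a few compounds, and the source may have more. Where it says the series, first, only, none or still open, it means among the compounds named here.

Of the compounds shown here, two have been measured in an assay for inhibition of arginase-1 (Homo sapiens), read by scintillation counting, with a stated time of 5 min, tested at 200 uM; on this read-out lower numbers stand for less inhibition and higher numbers for more inhibition at the one concentration tested (going by the name of the read-out). Compound 1 `Cc1cc(C(=O)O)c(O)c(=O)[nH]1` gives 8% in this assay. Compound 2 `Cc1cc(=O)c(O)c(C(=O)O)n1O` gives 12%, and the two numbers lie within the usual scatter of each other, so neither stands apart; both show only a small amount of inhibition at the concentration tested.

Compound 3 `CNC(=O)c1cc(C)[nH]c(=O)c1O` has not yet been measured. It differs from compound 1 in one place: methylamino in place of hydroxy on a carbonyl carbon. Going by the values given here, no measured pair in this set shows what such a change does, so the expectation rests on compound 1 alone, whose result of 8% already sits near the bottom of the read-out. The step from a number 3 percentage points lower from compound 1 to compound 3 (within the scatter) is expected to be none beyond the scatter, with a slight lean downward. Compound 3 is therefore estimated at 5%, in a range from 0% to 18%.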

Compound 3, a percentage reported as inhibition, at one concentration (the size of the read-out at that concentration, not a potency): 5%
The estimate for compound 3 equals the measured number at the digits printed; low and high end bracket the measured number.
By their numbers in this assay, from the lowest: compounds 3, 1 and 2 (each within the scatter of the next).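

Putting methylamino in place of hydroxy on a carbonyl carbon, which turns carboxy into methylcarbamoyl, gives a number 3 percentage points lower from compound 1 to compound 3 (within the scatter) in this assay. Going by these compounds alone, this is the first measured change in this set made at a single place, and it shows that the change does not lift the read-out beyond the scatter: compound 3 gives 5%, again only a small amount of inhibition at the one concentration tested. With numbers this low, the result says little about how much this position matters, since neither the acid nor the amide gives much signal to compare.

Still open, on these data alone, is how a plain unsubstituted amide, an amide with a longer chain, or an amine would read at this place. Nothing measured here offers a reason for the result.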